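A few compounds are considered here, and "the series" means these few. Any claim that something is new, unique, unknown or untested is made for them only; others in the source may bear on it.

Compound 1 `Cc1cc(C)cc(S(=O)(=O)c2c(C(=O)Nc3cccc(O)c3)[nH]c3ccc(Cl)cc23)c1`: 24600 nM
Compound 2 `Cc1cc(C)cc(S(=O)(=O)c2c(C(=O)Nc3ccc(O)cc3)[nH]c3ccc(Cl)cc23)c1`: 18100 nM
Compound 3 `Cc1cc(C)cc(S(=O)(=O)c2c(C(=O)NCc3ccccc3O)[nH]c3ccc(Cl)cc23)c1`: 23800 nM

In an ADME assay on MT4 cells (Homo sapiens) for cytotoxicity, read by MTT assay (a lower number here means that less compound is tolerated, a higher number that more compound is tolerated), compound 3 gives 23800 nM, within the scatter of both other compounds. Compound 4 `Cc1cc(C)cc(S(=O)(=O)c2c(C(=O)NCc3cccc(O)c3)[nH]c3ccc(Cl)cc23)c1` differs from compound 3 by 3-hydroxyphenyl in place of 2-hydroxyphenyl on a saturated chain carbon bound to an amide-type nitrogen, with 3-hydroxyphenyl in place of 2-hydroxyphenyl on a saturated chain carbon bound to an amide-type nitrogen. Going by the values given here, no measured step makes exactly this change. The closest ones alter the group on the amide-type nitrogen: a 1.4-fold lower number from compound 1 to compound 2 (0.13 log units; within the scatter), a 1.0-fold lower number from compound 1 to compound 3 (0.01 log units; within the scatter) and a 1.3-fold higher number from compound 2 to compound 3 (0.12 log units; within the scatter). All three lie within the scatter, so no step beyond the scatter is expected here. The expected change is a 1.1-fold lower number from compound 3 to compound 4 (0.03 log units; within the scatter). The estimate for compound 4 is 22000 nM, with an expected range of 12000 nM to 40000 nM.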

Compound 4, half-maximal cytotoxic concentration: 27000 nM
Compound 4: middle estimate off by 1.2-fold (0.09 log units), on the low side; measured number inside the range.
By their numbers in this assay, from the lowest: compounds 2, 3, 1 and 4 (each within the scatter of the next).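

Going by these compounds alone, replacing 2-hydroxybenzyl with 3-hydroxybenzyl tests this position directly for the first time in this assay and gives a 1.1-fold higher number from compound 3 to compound 4 (0.05 log units; within the scatter). The 3-hydroxybenzyl group of compound 4 also stays within the scatter of both hydroxyphenyl groups, with a 1.1-fold higher number from compound 1 to compound 4 (0.04 log units; within the scatter) and a 1.5-fold higher number from compound 2 to compound 4 (0.17 log units; within the scatter), so these four groups cannot be told apart here. Nothing available offers a reason for these numbers. On these data alone, whether a longer chain on the amide-type nitrogen, or an amine or a carboxylic acid in place of the hydroxyl, would move the number beyond the scatter remains open.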